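Working notes on a methyl step in a cell assay

A few compounds are considered here, and "the series" means these few. Any claim that something is new, unique, unknown or untested is made for them only; others in the source may bear on it.

Measured compounds:
compound 1 `Cc1ccc(-c2ccsc2S(=O)(=O)NCCNC(=O)Nc2cc(C(F)(F)F)cc(C(F)(F)F)c2)c(Oc2ccc(O)c(O)c2)c1` — 9700 nM
compound 2 `O=C(NCCNS(=O)(=O)c1sccc1-c1ccccc1Oc1ccc(O)c(O)c1)Nc1cc(C(F)(F)F)cc(C(F)(F)F)c1` — > 50000 nM
compound 3 `O=S(=O)(NCCNC(=S)Nc1cc(C(F)(F)F)cc(C(F)(F)F)c1)c1sccc1-c1ccccc1Oc1ccc(O)c(O)c1` — > 50000 nM

In a functional assay on HeLa cells (Homo sapiens) for inhibition, read by CCK-8 assay, with a stated time of 48 h (on this read-out higher numbers stand for weaker inhibition and lower numbers for stronger inhibition), compound 1 gives 9700 nM. For compound 2 the value > 50000 nM is a limit of this assay and not a number. For compound 3 the value > 50000 nM is likewise a limit and not a number. Compound 2 and compound 1 differ in one place (methyl in place of hydrogen on an aromatic carbon), and this gives an at least 5.1-fold lower number from compound 2 to compound 1 (0.71 log units; beyond the scatter); the size of that step is bounded only by the limit of > 50000 nM in this assay, at which 2 of the 3 values shown sit.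

Compound 4 `Cc1ccc(-c2ccsc2S(=O)(=O)NCCNC(=S)Nc2cc(C(F)(F)F)cc(C(F)(F)F)c2)c(Oc2ccc(O)c(O)c2)c1` is not yet measured. It differs from compound 3 by methyl in place of hydrogen on an aromatic carbon, the same kind of change as from compound 2 to compound 1, with the two place descriptions identical word for word. The difference between the cores of compound 2 and compound 3 is not broken down here.

For compound 4 the step of an at least 2.0-fold lower number from compound 3 to compound 4 (0.30 log units; that floor lies within the scatter) is expected, resting on compound 2 to compound 1 giving an at least 5.1-fold lower number from compound 2 to compound 1 (0.71 log units; beyond the scatter) and on compound 3 sitting at the limit of > 50000 nM in this assay, at which 2 of the 3 values shown sit. Compound 4 is estimated at 25000 nM, between 8000 nM and 50000 nM.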

Compound 4, half-maximal inhibitory concentration: 8000 nM
Compound 4: middle estimate off by 3.1-fold (0.49 log units), on the high side; the range from low to high includes it.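

In this assay, methyl in place of hydrogen on an aromatic carbon gives an at least 6.2-fold lower number from compound 3 to compound 4 (0.79 log units; beyond the scatter), so the change lowers the number on both cores shown: the same change on two cores in this assay, an at least 5.1-fold lower number (0.71 log units; beyond the scatter) from compound 2 to compound 1 and an at least 6.2-fold lower number (0.79 log units; beyond the scatter) from compound 3 to compound 4; the limit leaves it open whether they differ. Compound 3 stands at > 50000 nM, which is a limit of the assay and not a number. The two steps therefore show a shared direction and a floor for each size, but they do not show that the change is worth the same amount on each core, and two cores are too few to support a rule for the series: the limit of > 50000 nM in this assay, at which 2 of the 4 values shown sit.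

The compounds shown place the methyl at only one position, meta to the 3,4-dihydroxyphenoxy group and para to a large group, so it remains open whether a chlorine atom, a methoxy group or a longer chain such as ethyl there would give a similar step. On these data alone, it also remains open whether the methyl step would persist on a core without the 3,4-dihydroxyphenoxy group.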